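The compounds below may be only part of what the source reports. "The series", "measured", "known", "first", "only" and "open" are said of these compounds alone.

Compound 1, `Cc1ccc(S(=O)(=O)c2cnc3ccc(Cl)cc3c2N2CCC(C)CC2)cc1C`, in an assay on isolated protein for displacement of a labelled ligand from metabotropic glutamate receptor 5 (Homo sapiens), with a stated time of 60 min, tested at 1 uM; on this read-out lower numbers stand for less inhibition and higher numbers for more inhibition at the one concentration tested (going by the name of the read-out): 84%
Compound 2, `Cc1ccc(S(=O)(=O)c2cnc3ccc(Cl)cc3c2N2CCC(C)CC2)cc1`, in this assay: 95%

Compound 2 stands highest of the two numbers measured; its nearest neighbour is compound 1, and the step of a number 11 percentage points higher from compound 1 to compound 2 (beyond the scatter) lies beyond the scatter. That step came from removing one methyl group, hydrogen in place of methyl on an aromatic carbon.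

Compound 3, `CC1CCN(c2c(S(=O)(=O)c3cccc(F)c3)cnc3ccc(Cl)cc23)CC1`, has not yet been measured. It differs from compound 2 by 3-fluorophenyl in place of 4-methylphenyl on a sulfonyl sulfur. Going by the values given here, no measured step alters the 4-methylphenyl ring as a whole, so the single step between compound 1 and compound 2 bears on it only loosely: it shows that small changes around this ring shift the read-out modestly. A step of similar or smaller size is therefore expected, most likely downward from the high value of compound 2. Compound 3 is expected to give about 85%, within 60% to 98%, an estimated step of a number 10 percentage points lower from compound 2 to compound 3 (within the scatter).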

Compound 3, a percentage reported as inhibition, at one concentration (the size of the read-out at that concentration, not a potency): 58%
Compound 3: the middle estimate sits 27 percentage points above what was measured; the measured number lies below the stated range.
By their numbers in this assay, from the lowest: compound 3; then compound 1; then compound 2.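

Changing the whole aromatic group on the sulfonyl sulfur can move the number in this assay much further than removing one methyl did: 3-fluorophenyl in place of 4-methylphenyl gives a number 37 percentage points lower from compound 2 to compound 3 (beyond the scatter) and 3-fluorophenyl in place of 3,4-dimethylphenyl gives a number 26 percentage points lower from compound 1 to compound 3 (beyond the scatter) as the second step at this place. The position therefore does not accept every group of this size, as 4-methylphenyl and 3-fluorophenyl both count 7 heavy atoms and no hydrogen-bond donors or acceptors, yet their numbers differ widely. No measurement here accounts for the difference.

The fluorine arrives and the methyl leaves in the same change, so neither can be credited separately. A plain phenyl or a 4-fluorophenyl group would leave the same question to be tested.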